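Replacing a lactam ring with a methylpiperidine on the shared core

The source may hold more compounds than are shown below. What is called first, only, known or untested is meant among the compounds shown, and "the series" means these compounds.

Three analogues of one core have been characterised in an ADME assay on microsomes from liver (Rattus norvegicus) for metabolic stability, read by LC-MS, tested at 1 uM; a higher number here means that the compound lasts longer, a lower number that the compound disappears faster. Compound 1 `Cc1cccc(Sc2nn(CC3CCNCC3)c3ncnc(N)c23)c1` gives 0.433 h and compound 3 `CC(C)(C)n1nc(Oc2cc(F)cc(F)c2)c2c(N)ncnc21` gives 0.55 h. Compound 2 `Nc1ncnc2c1c(Oc1cccc(Cl)c1)nn2CC1CCNC(=O)C1` gives only a limit of the assay, > 1 h, so compound 2 stands at the limit of > 1 h in this assay, at which 1 of the 3 values shown sits, rather than at a number. Compound 4 `CN1CCC(Cn2nc(Oc3cccc(Cl)c3)c3c(N)ncnc32)CC1` has not yet been measured; it differs from compound 2 in one place: 1-methylpiperidin-4-yl in place of 2-oxopiperidin-4-yl on a saturated chain carbon bound to an aromatic nitrogen. Among the measured compounds shown here, no step between measured pairs is recorded here, so the size of this change is uncertain. Given that compound 1 sits at 0.433 h and compound 3 at 0.55 h, a step downward beyond the usual scatter is expected, an at least 2.0-fold lower number from compound 2 to compound 4 (0.30 log units; that floor lies within the scatter). Compound 4 is therefore expected to give about 0.5 h, between 0.25 h and 1.1 h.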

Compound 4, half-life: > 1 h
Compound 4: no number, only a limit; the forecaster's own chance of this, stated with the estimate: 20%; middle value at least 2.0-fold (0.30 log units) from the limit.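

In this assay compound 2 gives > 1 h, which is a limit. Among the compounds shown here, compound 4 gives > 1 h, also a limit, so no step between compound 2 and compound 4 can be read. On these data alone, whether 1-methylpiperidin-4-yl and 2-oxopiperidin-4-yl differ in half-life remains open.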